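A few compounds are considered here, and "the series" means these few. Any claim that something is new, unique, unknown or untested is made for them only; others in the source may bear on it.

Measured so far in an ADME assay on HaCaT cells (Homo sapiens) for cytotoxicity, read by MTT assay, with a stated time of 72 h; on this read-out higher numbers stand for weaker inhibition and lower numbers for stronger inhibition:
- compound 1, `Cc1cc(S(=O)(=O)/N=C(\N)n2nccc2-c2ccccc2)c(SCc2ccccc2)cc1Cl`: 18000 nM
- compound 2, `Cc1cc(S(=O)(=O)/N=C(\N)n2nccc2-c2ccccc2)c(SCc2cccc3ccccc23)cc1Cl`: 11000 nM

Going by the values given here, compound 2 holds the lowest of the two numbers, but its only neighbour, compound 1, lies within the scatter of it, so no order between the two is claimed. Among the compounds with values here, the single step, a 1.6-fold lower number from compound 1 to compound 2 (0.21 log units; within the scatter), is the only one that touches the position now in question.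

Compound 3, `Cc1cc(S(=O)(=O)/N=C(\N)n2nccc2-c2ccccc2)c(SCc2ccccc2C)cc1Cl`, is not yet measured. It differs from compound 2 as follows: 2-methylphenyl in place of naphthalen-1-yl on a saturated chain carbon bound to a sulfur. Within the data shown here, this change bears on the same position as the step from compound 1 to compound 2, which stayed within the scatter; with no other step at this position to draw on, the expectation is that compound 3 stays with its neighbours. The expected step is a 1.3-fold higher number from compound 2 to compound 3 (0.10 log units; within the scatter), that is, none beyond the scatter. Compound 3 is therefore estimated at 14000 nM in this assay, with a range from 6000 nM to 35000 nM.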

Compound 3, half-maximal inhibitory concentration: 18000 nM
For compound 3 the middle estimate is 1.3-fold (0.11 log units) below the measured one; low and high end bracket the measured number.
By their numbers in this assay, from the lowest: compounds 2, 1 and 3 (each within the scatter of the next).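

In this assay, the position now holds a third group, and 2-methylphenyl in place of naphthalen-1-yl gives a 1.6-fold higher number from compound 2 to compound 3 (0.21 log units; within the scatter), while methyl in place of hydrogen on an aromatic carbon gives no change at the digits printed from compound 1 to compound 3 (within the scatter). Phenyl, naphthalen-1-yl and 2-methylphenyl on a saturated chain carbon bound to a sulfur therefore all lie within the scatter of one another, so neither a second aromatic ring nor the added methyl separates these three compounds in this read-out. No evidence is available to account for this.

On these data alone, all three groups are aromatic and contain only carbon, so the effect of an amine, a carboxylic acid or a longer chain at this place remains open. As far as these compounds go, whether any such group would move the number beyond the scatter also remains open.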